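The source may report more compounds than this note shows. Statements on the series, on what has been measured and on what is new or still open speak of the compounds shown alone.

Compound 1 `NC(=S)N/N=C1/C=C(Nc2ccc(Cl)cc2)C(Nc2ccc(Cl)cc2)=NC1=O` gives the lowest of the two numbers in a functional assay on MCF7 cells (Homo sapiens) for antiproliferative activity, read by MTT assay, with a stated time of 72 h (a higher number here means a weaker inhibitor, a lower number a stronger inhibitor), where compound 1 gives 1370 nM. Among the measured compounds shown here, the only other measured compound, compound 2 `Cc1ccccc1NC1=C/C(=N/N=C(\N)SCc2ccccc2)C(=O)N=C1Nc1ccccc1C`, differs from it in more than one place and gives 16300 nM in this assay, a gap beyond the scatter. Compound 3 `N/C(=N\N=C1\C=C(Nc2ccc(Cl)cc2)C(Nc2ccc(Cl)cc2)=NC1=O)SCc1ccccc1` keeps the core of compound 1 and carries a group of 11 heavy atoms (8 carbon, 2 nitrogen, 1 sulfur; one six-membered aromatic ring of carbon only) in place of a group of 4 heavy atoms (1 carbon, 2 nitrogen, 1 sulfur; no ring), on a double-bonded nitrogen. For the measured compounds named here, no single measured step covers this change; since compound 2 carries the same entering group and gives 16300 nM, a step toward a weaker inhibitor is expected, a 3.3-fold higher number from compound 1 to compound 3 (0.52 log units; beyond the scatter). Compound 3 is therefore estimated at 4500 nM, between 1300 nM and 16000 nM.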

Compound 3, half-maximal inhibitory concentration: 7720 nM
Compound 3: the middle estimate sits 1.7-fold (0.23 log units) below what was measured, within the range that was stated.
By their numbers in this assay, from the lowest: compound 1; then compound 3; then compound 2.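

In this assay, the change at this double-bonded nitrogen can now be read on its own, with the core of compound 1 kept: the entering group, with its six-membered aromatic ring of carbon only, gives a 5.6-fold higher number from compound 1 to compound 3 (0.75 log units; beyond the scatter), a step beyond the scatter. The position therefore tolerates this much larger group, with a weaker but still measurable inhibitor. Nothing measured here bears on why the number rises.

Among the compounds shown here, only this one entering group has been compared with the original group at this position. Going by these compounds, whether a methyl group, a longer alkyl chain, an amine or a carboxylic acid in its place would give a lower or a higher number remains open.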